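Removing the chloro and the oxygen linker from compound 3

This account rests on a few compounds, and the source may have more. Where it says the series, first, only, none or still open, it means among the compounds named here.

Compound 3 `CC(C)C[C@@H](c1nc2ccc(C(=O)O)cc2n1C)N1C(=O)CN(c2ccc(Oc3ccc(Cl)cc3)cc2)C1=O` gives the lowest number of the three measured in an assay on isolated protein for inhibition of Bile acid receptor (Homo sapiens), read by TR-FRET and LanthaScreen (a higher number here means a weaker inhibitor, a lower number a stronger inhibitor), at 2560 nM. Compound 1 `CC(C)C[C@@H](c1nc2ccc(C(=O)O)cc2n1C)N1C(=O)CN(c2ccc(Oc3ccccc3)cc2)C1=O` gives 43400 nM and compound 2 `CC(C)C[C@@H](c1nc2ccc(C(=O)O)cc2n1C)N1C(=O)CN(c2ccc(OC3CCCCC3)cc2)C1=O` gives 126000 nM. Compound 4 `CC(C)C[C@@H](c1nc2ccc(C(=O)O)cc2n1C)N1C(=O)CN(c2ccc(-c3ccccc3)cc2)C1=O` carries phenyl in place of 4-chlorophenoxy on an aromatic carbon. The measured step of a 17-fold lower number from compound 1 to compound 3 (1.23 log units; beyond the scatter) shows how much the chloro alone is worth; the step of a 49-fold lower number from compound 2 to compound 3 (1.69 log units; beyond the scatter) shows the aromatic ring outweighing the saturated one, and a 2.9-fold higher number from compound 1 to compound 2 (0.46 log units; beyond the scatter) points the same way. Nothing measured separates the oxygen linker from the ring it carries. Compound 4 loses the chloro, so a large increase is expected, back toward compound 1 given 43400 nM. The expected step is a 12-fold higher number from compound 3 to compound 4 (1.07 log units; beyond the scatter). Compound 4 is estimated at 30000 nM, within 8000 nM to 120000 nM.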

Compound 4, half-maximal inhibitory concentration: 23100 nM
Compound 4: middle estimate off by 1.3-fold (0.11 log units), on the high side, and the stated range covers the measured number.
By their numbers in this assay, from the lowest: compound 3; then compounds 4 and 1 (each within the scatter of the next); then compound 2.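

In this assay phenyl in place of phenoxy gives a 1.9-fold lower number from compound 1 to compound 4 (0.27 log units; within the scatter) and so does not separate the two groups: without the chloro, the oxygen linker shows no effect beyond the scatter. Losing the chloro and the oxygen linker together gives a 9.0-fold higher number from compound 3 to compound 4 (0.96 log units; beyond the scatter) and returns to the level of compound 1, so this step tracks the chloro. Phenyl in place of cyclohexyloxy gives a 5.5-fold lower number from compound 2 to compound 4 (0.74 log units; beyond the scatter) and extends the lead of aromatic over saturated rings to a group without the linker.

As far as these compounds go, whether a chloro on the phenyl of compound 4 restores the gain seen with 4-chlorophenoxy, and whether bromo or methoxy can replace that chloro, stays open. No evidence at hand explains any of these steps.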